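Urea series: cytotoxicity limits and a chloro analogue

This account rests on a few compounds, and the source may have more. Where it says the series, first, only, none or still open, it means among the compounds named here.

Compound 1 `Cc1cc(NC(=O)Nc2ccc(N(C)C)cc2)c2ccccc2n1` is the reference point of the series. In an ADME assay on HepG2 cells (Homo sapiens) for cytotoxicity, with a stated time of 72 h (a higher number here means that more compound is needed for the effect, a lower number that less compound is needed), compound 1 gives only a limit, > 25000 nM, so no number is known for it. Compound 2 `Cc1cc(NC(=O)Nc2cnc3ccccc3c2)c2ccccc2n1` is the other measured member. In this assay compound 2 likewise reports a limit, > 25000 nM. Going by the values given here, both results rest on (the limit of > 25000 nM in this assay, at which 2 of the 2 values shown sit), and no step between measured compounds can be sized from them. Compound 3 `Cc1cc(NC(=O)Nc2ccc(Cl)cc2)c2ccccc2n1` has not yet been measured. It differs from compound 1 by chloro in place of dimethylamino on an aromatic carbon. Among the compounds with values here, with no measured step available, no shift beyond the usual scatter is expected from compound 1 to compound 3 in this assay, and the most probable outcome is that compound 3 again reports a limit rather than a number. The estimate for compound 3 in this assay is 30000 nM, within 10000 nM to 100000 nM. The expected step is a step that the limit leaves unreadable from compound 1 to compound 3.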

Compound 3, half-maximal effective concentration: > 25000 nM
Compound 3: only a limit was reported; the forecaster's own chance of this, stated with the estimate: 80%; the middle value is on the limit's open side.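

In this assay, going by these compounds alone, compound 1 and compound 3 each report only a limit, and no step between them can be read. The compounds shown leave open the concentration at which any of them reaches a half-maximal effect, and whether chloro and dimethylamino differ at all in this assay.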